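A Pyridine Ring Replaces Methoxyphenyl on the Core

The compounds below may be only part of what the source reports. "The series", "measured", "known", "first", "only" and "open" are said of these compounds alone.

Measured compounds:
compound 1, `CCCCNc1nc(N)nc2c1CN(C(=O)c1ccccc1)CC2`: 1.4 uM
compound 2, `CCCCNc1nc(N)nc2c1CN(Cc1c(Cl)cccc1Cl)CC2`: 0.14 uM
compound 3, `CCCCNc1nc(N)nc2c1CN(Cc1ccc(OC)cc1)CC2`: 0.08 uM

In an assay on HEK293 cells for agonist activity at Toll-like receptor 8 (Homo sapiens), read by a luciferase reporter, with a stated time of 6 h (a higher number here means that more compound is needed for the effect, a lower number that less compound is needed), compound 3 gives the smallest of the three numbers, yet its gap to compound 2 is within the scatter, while compound 1 stands far away at 1.4 uM. Compound 4, `CCCCNc1nc(N)nc2c1CN(Cc1ccncc1)CC2`, has not yet been measured. It differs from compound 3 in one place: pyridin-4-yl in place of 4-methoxyphenyl on a saturated chain carbon bound to an amine nitrogen in a ring. Within the data shown here, the one measured step that bears on this is the earlier swap of rings at the same place, a 1.8-fold lower number from compound 2 to compound 3 (0.24 log units; within the scatter), which stayed within the scatter. A further exchange of the ring here is therefore expected to move the number little, if at all. For compound 4 the estimate is 0.15 uM, in the range 0.05 uM to 0.5 uM, meaning an expected step of a 1.9-fold higher number from compound 3 to compound 4 (0.27 log units; within the scatter).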

Compound 4, minimum effective concentration: 0.29 uM
Estimate against measurement, compound 4: 1.9-fold (0.29 log units) below; the measured number falls inside the stated range.
By their numbers in this assay, from the lowest: compounds 3 and 2 (each within the scatter of the next); then compound 4; then compound 1.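

At this place the ring is not interchangeable: the pyridin-4-yl ring gives a 3.6-fold higher number from compound 3 to compound 4 (0.56 log units; beyond the scatter) and also a 2.1-fold higher number from compound 2 to compound 4 (0.32 log units; beyond the scatter), whereas the two carbon-only rings of compounds 2 and 3 stayed within the scatter of each other. Even so, a 4.8-fold lower number from compound 1 to compound 4 (0.68 log units; beyond the scatter) shows that compound 4, with its (pyridin-4-yl)methyl group, still needs less compound than the benzoyl amide. Nothing measured here explains the loss seen with the pyridine ring. Still open, going by these compounds, is how a saturated ring such as cyclohexyl, or a plain butyl chain, would behave at this place.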